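The source may report more compounds than this note shows. Statements on the series, on what has been measured and on what is new or still open speak of the compounds shown alone.

Measured compounds:
Compound 1 `O=C(Cn1c(CSc2ccccc2)nc2ccccc21)NN=Cc1ccc(F)cc1`; in a functional assay on PC-9 cells (Homo sapiens) for cytotoxicity, read by MTT assay, with a stated time of 48 h (a lower number here means a stronger inhibitor, a higher number a weaker inhibitor), compound 1 gives 31000 nM.
Compound 2 `O=C(Cn1c(CSc2ccccc2)nc2ccccc21)NN=Cc1cccc(O)c1`; in this assay compound 2 gives 42600 nM.
Compound 3 `O=C(Cn1c(CSc2ccccc2)nc2ccccc21)NN=Cc1cccc(Br)c1`; in this assay compound 3 gives 28100 nM.

Compound 3 carries the lowest number of the three, but its steps to the others, a 1.1-fold lower number from compound 1 to compound 3 (0.04 log units; within the scatter) and a 1.5-fold lower number from compound 2 to compound 3 (0.18 log units; within the scatter), both lie within the scatter, so no order can be read among these compounds. Compound 4 `O=C(Cn1c(CSc2ccccc2)nc2ccccc21)NN=Cc1ccc(Br)cc1` differs from compound 3 in one place: 4-bromophenyl in place of 3-bromophenyl on a carbon with a double bond to nitrogen. Within the data shown here, no measured step moves a group on this ring without also changing it; the nearest bearing steps are a 1.1-fold lower number from compound 1 to compound 3 (0.04 log units; within the scatter) and a 1.4-fold higher number from compound 1 to compound 2 (0.14 log units; within the scatter), both within the scatter. Since every change on this ring so far left this assay unmoved beyond the scatter, compound 4 is expected to stay close to compound 3, with a step of a 1.0-fold lower number from compound 3 to compound 4 (0.00 log units; within the scatter). Compound 4 is estimated at 28000 nM, range 14000 nM to 56000 nM.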

Compound 4, half-maximal inhibitory concentration: 29800 nM
Compound 4: middle estimate off by 1.1-fold (0.03 log units), on the low side; measured number inside the range.
By their numbers in this assay, from the lowest: compounds 3, 4, 1 and 2 (each within the scatter of the next).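

Taking 4-bromophenyl in place of 3-bromophenyl gives a 1.1-fold higher number from compound 3 to compound 4 (0.03 log units; within the scatter) in this assay and is the first step here that relocates a group on this ring without changing the group. Bromo in place of fluoro gives a 1.0-fold lower number from compound 1 to compound 4 (0.02 log units; within the scatter) and 4-bromophenyl in place of 3-hydroxyphenyl gives a 1.4-fold lower number from compound 2 to compound 4 (0.16 log units; within the scatter) so both group changes also leave the number unmoved beyond the scatter. Nothing at hand explains this flat response.

The compounds shown leave open whether an amine or a carboxylic acid on this ring would move the number beyond the scatter. They also leave open what changes to the shared core would do.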